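The source may report more compounds than this note shows. Statements on the series, on what has been measured and on what is new or still open speak of the compounds shown alone.

Measured compounds:
compound 1, `CN(C)c1[nH]ccc2ncnc1-2`, 8%
compound 2, `CN(C)c1nccc2c1ncn2C1O[C@H](CO)[C@@H](O)[C@H]1O`, 0%
compound 3, `[N-]=[N+]=Nc1nccc2c1ncn2C1O[C@H](CO)[C@@H](O)[C@H]1O`, 4%

All three were tested in a functional assay (Homo sapiens) for inhibition of Nucleic Acid, tested at 100 uM; on this read-out lower numbers stand for less inhibition and higher numbers for more inhibition at the one concentration tested (going by the name of the read-out). The values of compound 1, compound 2 and compound 3 lie within the scatter of one another, so the inhibition in this assay is level among them. From compound 2 to compound 3 the change is azido in place of dimethylamino on an aromatic carbon, and it gave a number 4 percentage points higher from compound 2 to compound 3 (within the scatter). Compound 4, `[N-]=[N+]=Nc1[nH]ccc2ncnc1-2`, is not yet measured; it arises from compound 1 by azido in place of dimethylamino on an aromatic carbon, the same change at the same place. The difference between the two cores of compound 1 and compound 2 is not broken down here. Because a number 4 percentage points higher from compound 2 to compound 3 (within the scatter) was within the scatter, the step from compound 1 to compound 4 in this assay is expected to be similar, about a number 2 percentage points higher from compound 1 to compound 4 (within the scatter). Compound 4 is therefore estimated at 10%, between 0% and 22%.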

Compound 4, a percentage reported as inhibition, at one concentration (the size of the read-out at that concentration, not a potency): 20%
Estimate against measurement, compound 4: 10 percentage points below, and the stated range covers the measured number.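

Azido in place of dimethylamino gave a number 12 percentage points higher from compound 1 to compound 4 (beyond the scatter) in this assay. Set beside the same change on the other core, this step does not differ from the earlier one by more than the measurements can resolve: the same change on two cores in this assay, a number 4 percentage points higher (within the scatter) from compound 2 to compound 3 and a number 12 percentage points higher (beyond the scatter) from compound 1 to compound 4, 8 percentage points apart, within the scatter of two such steps. So the change can be said to carry over between these two cores in this assay, but only one of the two steps lies beyond the scatter, and two pairs cannot show that it would hold on any further core.

The compounds shown leave open how other groups on this aromatic carbon would read, such as a simple amine, a methoxy group or chlorine. They also leave open what a carboxylic acid elsewhere on either core would do.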